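The source may report more compounds than this note shows. Statements on the series, on what has been measured and on what is new or still open speak of the compounds shown alone.

Measured compounds:
compound 1, `CCCCC(NC(=O)c1ccc(N)cc1)c1ccccc1` — 73.7 mg/kg
compound 2, `CNCc1ccc(C(=O)NC(C)c2ccccc2)cc1` — 13.5 mg/kg

Going by the values given here, in a functional assay on the whole organism with Mus musculus as the target (on this read-out lower numbers stand for an effect already at smaller amounts and higher numbers for an effect only at larger amounts of compound), compound 2 stands lowest of the two numbers; the only neighbour, compound 1, lies beyond the scatter above it. No pair of measured compounds differs in a single place, so nothing shown tells how methyl in place of hydrogen on an amine nitrogen shifts the read-out.

Compound 3, `CC(NC(=O)c1ccc(CN(C)C)cc1)c1ccccc1`, carries this change relative to compound 2. With no comparable step shown, the expected step of a 1.1-fold higher number from compound 2 to compound 3 (0.05 log units; within the scatter) is none beyond the scatter. Compound 3 is therefore estimated at 15 mg/kg, expected to fall between 6 mg/kg and 40 mg/kg.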

Compound 3, dose for half-maximal effect: 13 mg/kg
Compound 3: middle estimate off by 1.2-fold (0.06 log units), on the high side; the measured number falls inside the stated range.
By their numbers in this assay, from the lowest: compounds 3 and 2 (each within the scatter of the next); then compound 1.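

In this assay, going by these compounds alone, methyl in place of hydrogen on the amine nitrogen gives a 1.0-fold lower number from compound 2 to compound 3 (0.02 log units; within the scatter) and is the first single-place step. Taking (methylamino)methyl to (dimethylamino)methyl therefore adds one carbon at this nitrogen without moving the number beyond the scatter. Nothing available explains this result.

Still open, on these data alone, is whether a longer chain on this nitrogen, such as ethyl or propyl, would leave the number similarly unmoved. A primary amine at this position also remains untested among the compounds shown.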